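From an ethyl amide to an acetoxymethyl group

This account rests on a few compounds, and the source may have more. Where it says the series, first, only, none or still open, it means among the compounds named here.

Compound 1 `Cc1cc(CCC#N)cc(C)c1Oc1cc(Nc2ccc(C#N)cc2)c(N)cc1C(=O)N(C)C`: 38200 nM
Compound 2 `CCNC(=O)c1cc(N)c(Nc2ccc(C#N)cc2)cc1Oc1c(C)cc(CCC#N)cc1C`: 105000 nM
Compound 3 `Cc1cc(CCC#N)cc(C)c1Oc1cc(Nc2ccc(C#N)cc2)c(N)cc1C(=O)NC1CC1`: 121000 nM

In an ADME assay on TZM cells (Homo sapiens) for cytotoxicity, with a stated time of 1 days (a lower number here means that less compound is tolerated, a higher number that more compound is tolerated), compound 2 gives 105000 nM, level with compound 3 within the scatter and clear of compound 1. Compound 4 `CC(=O)OCc1cc(N)c(Nc2ccc(C#N)cc2)cc1Oc1c(C)cc(CCC#N)cc1C` departs from compound 2 in one place: acetoxymethyl in place of ethylcarbamoyl on an aromatic carbon.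

Going by the values given here, three measured steps touch the amide. Two were modest, a 2.7-fold higher number from compound 1 to compound 2 (0.44 log units; beyond the scatter) and a 3.2-fold higher number from compound 1 to compound 3 (0.50 log units; beyond the scatter), while a 1.2-fold higher number from compound 2 to compound 3 (0.06 log units; within the scatter) stayed within the scatter. None removes the amide, so they offer only a rough scale. Compound 1, whose amide lacks a hydrogen, gives 38200 nM. Compound 4 has no amide hydrogen either, so a modest step down is expected, though this rests on thin evidence. The estimated change is a 2.3-fold lower number from compound 2 to compound 4 (0.37 log units; beyond the scatter). For compound 4 the expected value is 45000 nM, with an estimated range of 14000 nM to 120000 nM.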

Compound 4, half-maximal cytotoxic concentration: 44800 nM
Beside the measured number, compound 4's estimate is 1.0-fold (0.00 log units) above it; the measured number falls inside the stated range.
By their numbers in this assay, from the lowest: compounds 1 and 4 (each within the scatter of the next); then compounds 2 and 3 (each within the scatter of the next).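

Going by these compounds alone, compound 4 is the only compound here without an amide at this aromatic carbon, and the change gives a 2.3-fold lower number from compound 2 to compound 4 (0.37 log units; beyond the scatter) and a 2.7-fold lower number from compound 3 to compound 4 (0.43 log units; beyond the scatter), while a 1.2-fold higher number from compound 1 to compound 4 (0.07 log units; within the scatter) stays within the scatter. In this assay, the two compounds lacking an amide hydrogen, compound 1 and compound 4, thus sit together below compound 2 and compound 3, and none of the four goes against this split. Nothing available explains the split.

The compounds shown leave open where a hydroxymethyl group or a carboxylic acid on this aromatic carbon would fall.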